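Methyl-to-hydrogen step on the ring nitrogen of compound 2

This account rests on a few compounds, and the source may have more. Where it says the series, first, only, none or still open, it means among the compounds named here.

Measured so far:
compound 1, `c1cc(N2CCCCC2)nc(Nc2ccc(Oc3ncnc4sccc34)cc2)n1`, 64.8%
compound 2, `CN(c1ccc(Oc2ncnc3sccc23)cc1)c1nccc(N2CCCC2)n1`, 55.5%

In a functional assay on A549 cells (Homo sapiens) for inhibition, read by MTT assay, with a stated time of 72 h, tested at 20 uM (on this read-out lower numbers stand for less inhibition and higher numbers for more inhibition at the one concentration tested (going by the name of the read-out)), compound 1 gives 64.8% and compound 2 gives 55.5%. Compound 2 has the lower of the two numbers, but its gap to compound 1 lies within the usual scatter of the read-out, so the two cannot be told apart on these data. Compound 3 is `c1cc(N2CCCC2)nc(Nc2ccc(Oc3ncnc4sccc34)cc2)n1` and is not yet measured in this assay. The change from compound 2 to compound 3 is hydrogen in place of methyl on a nitrogen on an aromatic ring. Among the measured compounds shown here, no pair of measured compounds differing in one place is available, so no measured step can be set against this change. With only a single heavy atom removed and no ring, donor or acceptor count altered, a step in this assay of no size beyond the scatter is expected for compound 3 in either direction, and the value of compound 3 is expected to sit near that of compound 2. The estimate for compound 3 in this assay is 62%, with a range from 45% to 78%, which means an expected step of a number 6.5 percentage points higher from compound 2 to compound 3 (within the scatter).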

Compound 3, a percentage reported as inhibition, at one concentration (the size of the read-out at that concentration, not a potency): 61%
Compound 3: the middle estimate sits 1 percentage points above what was measured, within the range that was stated.
By their numbers in this assay, from the lowest: compounds 2, 3 and 1 (each within the scatter of the next).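

In this assay, among the compounds shown here, the change to hydrogen in place of methyl on a nitrogen on an aromatic ring gives a number 5.5 percentage points higher from compound 2 to compound 3 (within the scatter) and so provides the first one-place reading at this nitrogen: on this read-out, the methyl and hydrogen forms cannot be told apart. Compound 3 also connects to compound 1 through a second one-place change, pyrrolidin-1-yl in place of piperidin-1-yl on an aromatic carbon, which gives a number 3.8 percentage points lower from compound 1 to compound 3 (within the scatter) and likewise cannot be resolved in this assay. Thus neither of the two places has yet produced a step beyond the scatter, and nothing available here bears on the reason for either step.

From the compounds shown here alone, it remains open whether a larger group on the same nitrogen, such as an ethyl group, a longer alkyl chain or an acetyl group, would move the number beyond the scatter, and whether a morpholine or an open-chain dimethylamino group on the aromatic carbon would do so. Going by these compounds, because each compound is read at one concentration, the potency of all three compounds also remains open.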